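Notes on a nitrophenyl isomer step in the series

The source may hold more compounds than are shown below. What is called first, only, known or untested is meant among the compounds shown, and "the series" means these compounds.

Measured in a functional assay on MDA-MB-231 cells (Homo sapiens) for antiproliferative activity, read by MTT assay, with a stated time of 72 h; a higher number here means a weaker inhibitor, a lower number a stronger inhibitor:
- compound 1 `CC1=CC[C@H]2[C@H](CC[C@]2(C)O)C(C)(C)[C@@H]1CC[C@H]1[C@]2(C)CC[C@H](OC(=O)c3ccc(Cl)cc3)C(C)(C)O[C@H]2CC[C@@]1(C)O` gives 10300 nM
- compound 2 `CC1=CC[C@H]2[C@H](CC[C@]2(C)O)C(C)(C)[C@@H]1CC[C@H]1[C@]2(C)CC[C@H](OC(=O)c3ccc(Cl)c(Cl)c3)C(C)(C)O[C@H]2CC[C@@]1(C)O` gives 8100 nM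
- compound 3 `CC1=CC[C@H]2[C@H](CC[C@]2(C)O)C(C)(C)[C@@H]1CC[C@H]1[C@]2(C)CC[C@H](OC(=O)c3cccc([N+](=O)[O-])c3)C(C)(C)O[C@H]2CC[C@@]1(C)O` gives 34700 nM

Compound 3 has the highest number of the three and is the weakest inhibitor so far. Two modest steps beyond the scatter lead to it: a 3.4-fold higher number from compound 1 to compound 3 (0.53 log units; beyond the scatter) and a 4.3-fold higher number from compound 2 to compound 3 (0.63 log units; beyond the scatter). Chloro in place of hydrogen on an aromatic carbon gives a 1.3-fold lower number from compound 1 to compound 2 (0.10 log units; within the scatter) and stays within the scatter.

The next compound is compound 4 `CC1=CC[C@H]2[C@H](CC[C@]2(C)O)C(C)(C)[C@@H]1CC[C@H]1[C@]2(C)CC[C@H](OC(=O)c3ccccc3[N+](=O)[O-])C(C)(C)O[C@H]2CC[C@@]1(C)O`, which has the same atoms as compound 3 joined differently: 2-nitrophenyl in place of 3-nitrophenyl on a carbonyl carbon. It carries 2-nitrophenyl in place of 3-nitrophenyl on a carbonyl carbon.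

Among the compounds with values here, no measured step moves a nitro group, so direct precedent is lacking. The steps into compound 3 exchange a chlorophenyl group for a nitrophenyl group, and the larger of them, a 4.3-fold higher number from compound 2 to compound 3 (0.63 log units; beyond the scatter), gives only a rough upper scale for a change at this place. No step beyond the scatter is therefore expected in this assay, and no direction is favoured. The expected step is a 1.2-fold lower number from compound 3 to compound 4 (0.06 log units; within the scatter) and would stay small. The estimate for compound 4 is 30000 nM with an expected range from 13000 nM to 70000 nM around it.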

Compound 4, half-maximal inhibitory concentration: 38700 nM
For compound 4 the middle estimate is 1.3-fold (0.11 log units) below the measured one, and the stated range covers the measured number.
By their numbers in this assay, from the lowest: compounds 2 and 1 (each within the scatter of the next); then compounds 3 and 4 (each within the scatter of the next).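

In this assay, within the data shown here, 2-nitrophenyl in place of 3-nitrophenyl on the carbonyl carbon gives a 1.1-fold higher number from compound 3 to compound 4 (0.05 log units; within the scatter) and is the first measured step to move the nitro group, showing that in this pair its placement does not separate the two compounds. The exchange of chlorophenyl for nitrophenyl now holds for both nitrophenyl isomers, with a 3.8-fold higher number from compound 1 to compound 4 (0.57 log units; beyond the scatter) and a 4.8-fold higher number from compound 2 to compound 4 (0.68 log units; beyond the scatter) both beyond the scatter, so among these four compounds the kind of substituted phenyl group matters more at this place than where the nitro group stands. Nothing at hand bears on what lies behind this difference between the nitrophenyl and chlorophenyl compounds.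

The compounds shown leave open whether 4-nitrophenyl would stay with the two nitrophenyl isomers, which would also give a direct comparison with the 4-chlorophenyl group of compound 1. They also leave open how the number would respond to an amine or a carboxylic acid on the phenyl ring in place of the nitro group, or to a longer chain between the carbonyl and that ring.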